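A few compounds are considered here, and "the series" means these few. Any claim that something is new, unique, unknown or untested is made for them only; others in the source may bear on it.

Measured so far:
- compound 1 `CC(C)=CCC/C(C)=C\CCC(C)=CCNCCN`: 32300 nM
- compound 2 `CC(C)=CCC/C(C)=C\CCC(C)=CCNCCCN1CCCC1`: 85300 nM

In a toxicity assay on CHO cells (Cricetulus griseus) for cytotoxicity, read by WST assay, with a stated time of 24 h (on this read-out lower numbers stand for stronger inhibition and higher numbers for weaker inhibition), compound 1 has the lower of these two numbers, so it is the stronger inhibitor of the pair. Compound 3 `CC(C)=CCC/C(C)=C\CCC(C)=CCNCCNCCNCCNCCN` differs from compound 1 by 2-((2-((2-aminoethyl)amino)ethyl)amino)ethyl in place of hydrogen on an amine nitrogen on its amine nitrogen. For the measured compounds named here, only one measured step bears on this, and only loosely since its change is a different one: a 2.6-fold higher number from compound 1 to compound 2 (0.42 log units; beyond the scatter) is modest. A similarly small rise is therefore expected in this assay with an estimated 1.5-fold higher number from compound 1 to compound 3 (0.19 log units; within the scatter) and little confidence in the direction. Compound 3 is estimated at 50000 nM with an expected range from 15000 nM to 150000 nM for now.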

Compound 3, half-maximal inhibitory concentration: 43500 nM
Beside the measured number, compound 3's estimate is 1.1-fold (0.06 log units) above it, within the range that was stated.
By their numbers in this assay, from the lowest: compounds 1, 3 and 2 (each within the scatter of the next, the first and the last beyond it).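

In this assay, 2-((2-((2-aminoethyl)amino)ethyl)amino)ethyl in place of hydrogen on an amine nitrogen gives a 1.3-fold higher number from compound 1 to compound 3 (0.13 log units; within the scatter). This nitrogen, whose other neighbour is a saturated chain carbon, therefore carries a chain of 9 heavy atoms with no difference beyond the usual scatter. No measured evidence accounts for this result. The compounds shown leave open how a small group such as methyl, or a carboxylic acid at the end of the chain, would read in this assay.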